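Ethoxy in Place of Chloro: a Weak Series Continues

A few compounds are considered here, and "the series" means these few. Any claim that something is new, unique, unknown or untested is made for them only; others in the source may bear on it.

Compound 1 `Fc1ccc2nc(Nc3nc4ccccc4s3)sc2c1` is a weak inhibitor in a functional assay on U-937 cells (Homo sapiens) for cytotoxicity, read by MTT assay, with a stated time of 48 h; a higher number here means a weaker inhibitor, a lower number a stronger inhibitor: compound 1 gives 40600 nM; 43500 nM (2 entries). Compound 2 `Clc1ccc2nc(Nc3nc4ccccc4s3)sc2c1` reaches only a limit of this assay, > 50000 nM, so no number stands for it. Compound 3 `CCOc1ccc2nc(Nc3nc4ccccc4s3)sc2c1` differs from compound 2 by ethoxy in place of chloro on an aromatic carbon. Among the compounds with values here, with no measured step to lean on, and given that both measured compounds sit at the weak end the several entries of compound 1 in this assay, 40600 nM; 43500 nM (2 entries) (the limit of > 50000 nM in this assay, at which 1 of the 2 values shown sits), the step of an at least 1.1-fold lower number from compound 2 to compound 3 (0.04 log units; that floor lies within the scatter) is expected to be small, within the scatter, with a limit again likely. Compound 3 is therefore estimated at 45000 nM in this assay, with a range from 20000 nM to 100000 nM.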

Compound 3, half-maximal inhibitory concentration: > 50000 nM
Compound 3: only a limit was reported (the forecaster's own chance of this, stated with the estimate: 50%); at least 1.1-fold (0.04 log units) between middle value and limit.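

In this assay compound 3 gives only the limit > 50000 nM and no number. Compound 2 also gives only a limit, so the step from compound 2 to compound 3 cannot be read. From the compounds shown here alone, whether ethoxy in place of chloro changes the inhibition at all stays open.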